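Sulfonamide-to-carbonyl swap in a series stuck at the limit

A few compounds are considered here, and "the series" means these few. Any claim that something is new, unique, unknown or untested is made for them only; others in the source may bear on it.

Compound 1 `COc1ccc(S(=O)(=O)Nc2ccc(-c3nc4cc(NS(=O)(=O)c5ccc(OC)cc5)ccc4o3)cc2)cc1` is the parent of this pair. In an assay on isolated protein for inhibition of thiosulfate sulfurtransferase (Homo sapiens) (a lower number here means a stronger inhibitor, a higher number a weaker inhibitor), compound 1 reaches only the limit of > 100000 nM. Compound 2 `COc1ccc(S(=O)(=O)Nc2ccc3oc(-c4ccc(NS(=O)(=O)c5cc(Br)ccc5OC)cc4)nc3c2)cc1` carries a 5-bromo-2-methoxyphenyl in place of the 4-methoxyphenyl on one sulfonyl sulfur; in this assay compound 2 likewise gives only the limit of > 100000 nM. The step that the two limits leave unreadable from compound 1 to compound 2 is accordingly unreadable, both values sitting at the limit of > 100000 nM in this assay, at which 2 of the 2 values shown sit. Compound 2 thus stands at the limit with no number to compare. Compound 3 `COc1ccc(S(=O)(=O)Nc2ccc3oc(-c4ccc(NC(=O)C5CCN(C(C)=O)CC5)cc4)nc3c2)cc1` differs from compound 2 by (1-acetylpiperidin-4-yl)carbonyl in place of (5-bromo-2-methoxyphenyl)sulfonyl on a nitrogen on an aromatic ring. Going by the values given here, no measured step reads on this change: the one step available is unreadable, and nothing measured exchanges a sulfonyl for a carbonyl on this nitrogen. Compound 3 is therefore expected to remain at the limit in this assay, with an estimated step of a number no higher from compound 2 to compound 3 (the limit leaves the size open). For compound 3 the estimate is 100000 nM, range 30000 nM to 300000 nM, most likely reported as a limit.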

Compound 3, half-maximal inhibitory concentration: > 100000 nM
Compound 3: a limit, no number; the forecaster's own chance of this, stated with the estimate: 75%; the middle value lies on the limit itself.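

Compound 3 sits at a limit, not a number, as do compound 1 and compound 2, so no step among the three can be read in this assay: the limit of > 100000 nM in this assay, at which 3 of the 3 values shown sit.

The compounds shown leave open how strongly any of the three inhibits, and whether any of the exchanged groups changes inhibition at all.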